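The source may report more compounds than this note shows. Statements on the series, on what has been measured and on what is new or still open speak of the compounds shown alone.

Measured so far in a functional assay on MDA-MB-435 cells (Homo sapiens) for antiproliferative activity, read by MTT assay, with a stated time of 5 days; a lower number here means a stronger inhibitor, a higher number a weaker inhibitor:
compound 1 `COc1cc[nH]c1/C=C1\C(=O)Nc2ccc([N+](=O)[O-])c(N3CC[C@@H](O)C3)c21` — 88 nM
compound 2 `COc1cc[nH]c1/C=C1\C(=O)Nc2ccc([N+](=O)[O-])c(N[C@H]3CC[C@H](O)C3)c21` — 1000 nM
compound 3 `COc1cc[nH]c1/C=C1\C(=O)Nc2ccc([N+](=O)[O-])c(N[C@H]3CC[C@H](O)CC3)c21` — 8550 nM

Compound 3 gives the highest number of the three: an 8.6-fold higher number from compound 2 to compound 3 (0.93 log units; beyond the scatter) and a 97-fold higher number from compound 1 to compound 3 (1.99 log units; beyond the scatter). The step considered is to compound 4 `COc1cc[nH]c1/C=C1\C(=O)Nc2ccc([N+](=O)[O-])c(N3CCCC(O)C3)c21`: 3-hydroxypiperidin-1-yl in place of (4-hydroxycyclohexyl)amino on an aromatic carbon. Among the compounds with values here, two measured steps bear on it. Both an 11-fold higher number from compound 1 to compound 2 (1.06 log units; beyond the scatter) and a 97-fold higher number from compound 1 to compound 3 (1.99 log units; beyond the scatter) replace 3-hydroxypyrrolidin-1-yl by (3-hydroxycyclopentyl)amino or (4-hydroxycyclohexyl)amino and give a large rise in the number; the present change runs the other way, bringing back a group of the 3-hydroxypyrrolidin-1-yl kind, now 3-hydroxypiperidin-1-yl, so a large fall in this assay is expected. The step of an 8.6-fold higher number from compound 2 to compound 3 (0.93 log units; beyond the scatter), in which a six-membered group replaces a five-membered one, hints that the six-membered variant may not fully reach the number of compound 1. Compound 4 is expected at 200 nM (range 60 nM to 800 nM). The expected step is a 43-fold lower number from compound 3 to compound 4 (1.63 log units; beyond the scatter).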

Compound 4, half-maximal inhibitory concentration: 250 nM
The estimate for compound 4 lay 1.3-fold (0.10 log units) below the measured number; measured number inside the range.
By their numbers in this assay, from the lowest: compound 1; then compound 4; then compound 2; then compound 3.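

In this assay, the position on the aromatic carbon ortho to the nitro group tolerates a six-membered ring when the ring holds the hetero atom: a 34-fold lower number from compound 3 to compound 4 (1.53 log units; beyond the scatter) and a 4.0-fold lower number from compound 2 to compound 4 (0.60 log units; beyond the scatter). Across the four compounds, both cyclic amines, compound 1 and compound 4, give lower numbers than both carbocyclic amino groups, compound 2 and compound 3, with no compound against this, although a 2.8-fold higher number from compound 1 to compound 4 (0.45 log units; beyond the scatter) shows that 3-hydroxypiperidin-1-yl does not match 3-hydroxypyrrolidin-1-yl. No measurement is available that explains these differences.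

From the compounds shown here alone, compound 4 carries no defined stereocentre, so the contribution of each hydroxyl orientation in 3-hydroxypiperidin-1-yl remains open. The compounds shown also leave open how 4-hydroxypiperidin-1-yl, unsubstituted piperidin-1-yl or a basic amine such as piperazin-1-yl would behave at this position.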